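Methylating the phenol of compound 1: an expected null step

The compounds below may be only part of what the source reports. "The series", "measured", "known", "first", "only" and "open" are said of these compounds alone.

In a functional assay on NCI-H460 cells (Homo sapiens) for inhibition, read by sulforhodamine B assay, with a stated time of 48 h, tested at 0.1 uM (on this read-out lower numbers stand for a stronger effect and higher numbers for a weaker effect at the one concentration tested), compound 1, `O=C(Nc1cccc(-n2cc(-c3ccncc3)c(-c3cc(O)cc(Cl)c3)n2)c1)Nc1ccc(Cl)c(C(F)(F)F)c1`, gives 102%, the highest of the two numbers recorded. Within the data shown here, its only measured neighbour is compound 2, `O=C(Nc1cccc(-n2cc(-c3ccncc3)c(-c3cc(O)cc(Cl)c3)n2)c1)Nc1ccc(Cl)c(Cl)c1`, which in this assay gives 97%. The step of a number 5 percentage points lower from compound 1 to compound 2 (within the scatter) comes from chloro in place of trifluoromethyl on an aromatic carbon, and the two values cannot be told apart.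

Compound 3, `COc1cc(Cl)cc(-c2nn(-c3cccc(NC(=O)Nc4ccc(Cl)c(C(F)(F)F)c4)c3)cc2-c2ccncc2)c1`, has not yet been measured in this assay. It differs from compound 1 as follows: methyl in place of hydrogen on an oxygen on an aromatic ring. Cut one bond further out, the same difference reads hydroxy to methoxy, 3-chloro-5-hydroxyphenyl to 3-chloro-5-methoxyphenyl.

Among the measured compounds shown here, none of the measured steps touches this oxygen. For the measured compounds named here, the only step recorded, a number 5 percentage points lower from compound 1 to compound 2 (within the scatter), concerns a distant aromatic carbon and stayed within the scatter, so there is no measured guide for the methylation itself, and both measured compounds sit at the top of the scale. Compound 3 is therefore expected to give 100% in this assay, with a range from 85% to 115%. The expected step is accordingly a number 2 percentage points lower from compound 1 to compound 3 (within the scatter), none beyond the scatter.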

Compound 3, a percentage reported as activity, at one concentration (the size of the read-out at that concentration, not a potency): 102%
Compound 3: middle estimate off by 2 percentage points, on the low side; measured number inside the range.
By their numbers in this assay, from the lowest: compounds 2, 1 and 3 (each within the scatter of the next).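

Methyl in place of hydrogen on this oxygen gives no change at the digits printed from compound 1 to compound 3 (within the scatter) in this assay, the first reading at this position, so 3-chloro-5-hydroxyphenyl and 3-chloro-5-methoxyphenyl cannot be told apart at the one concentration tested. The earlier step concerned a distant aromatic carbon, whereas this one shows that the same flat read-out holds when the hydroxy itself is replaced. Since compound 1 already stands at the weak end of the read-out, the step shows only that methylation brings out no effect, not that an effect was kept, and nothing at hand explains the result.

As far as these compounds go, what remains open is whether a longer chain on this oxygen, such as ethyl or 2-methoxyethyl, or an amine or a carboxylic acid in place of the hydroxy, would move the number at all. Also open, from the compounds shown here alone, is whether hydroxy and methoxy would separate at a concentration where the series gives a clear effect, which a single reading at the weak end cannot tell.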